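Swapping a Nitro for a Methyl on the Pendant Ring

The compounds below may be only part of what the source reports. "The series", "measured", "known", "first", "only" and "open" are said of these compounds alone.

The three measured compounds and their values:
compound 1 `O=C1/C(=C/c2ccccc2Cl)Cc2ccccc21`, 128000 nM
compound 2 `O=C1/C(=C/c2ccccc2F)Cc2ccccc21`, 54200 nM
compound 3 `O=C1/C(=C/c2ccccc2[N+](=O)[O-])Cc2ccccc21`, 2540 nM

In a functional assay on Molt4/C8 cells (Homo sapiens) for inhibition (a higher number here means a weaker inhibitor, a lower number a stronger inhibitor), compound 3 stands lowest of the three, which means it is the strongest inhibitor here. Its nearest neighbour is compound 2, and the gap to it is large: a 21-fold lower number from compound 2 to compound 3 (1.33 log units; beyond the scatter). The gap to compound 1 is larger still: a 50-fold lower number from compound 1 to compound 3 (1.70 log units; beyond the scatter). Between the two halogen compounds the difference is only modest: a 2.4-fold lower number from compound 1 to compound 2 (0.37 log units; beyond the scatter).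

Compound 4 `Cc1ccccc1/C=C1\Cc2ccccc2C1=O` has not yet been measured. It differs from compound 3 in one place: methyl in place of nitro on an aromatic carbon. Within the data shown here, the steps that bear on this are the two that lead to compound 3, since both replace a group at this same position with the nitro group and both give large drops in the number. Removing the nitro group again, in favour of a methyl group, is therefore expected to reverse that gain and move the number back up by a large amount, toward the region of compounds 1 and 2. Among the measured compounds shown here, no measured step pairs methyl with another group here, so the size is uncertain.

Compound 4 is expected to give about 60000 nM in this assay, within a range from 15000 nM to 250000 nM. The step this implies is expected to be a 24-fold higher number from compound 3 to compound 4 (1.37 log units; beyond the scatter).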

Compound 4, half-maximal inhibitory concentration: 154000 nM
Estimate against measurement, compound 4: 2.6-fold (0.41 log units) below, and the stated range covers the measured number.
By their numbers in this assay, from the lowest: compound 3; then compound 2; then compounds 1 and 4 (each within the scatter of the next).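

In this assay, the methyl group does not keep any visible part of what the nitro group gives at this aromatic carbon: the change is a 61-fold higher number from compound 3 to compound 4 (1.78 log units; beyond the scatter). It also puts compound 4 among the halogen compounds rather than in some middle ground. Against the chloro compound the change is a 1.2-fold higher number from compound 1 to compound 4 (0.08 log units; within the scatter), which leaves the two indistinguishable. Against the fluoro compound the change is a 2.8-fold higher number from compound 2 to compound 4 (0.45 log units; beyond the scatter), only a modest step. Across these four compounds, then, the nitro group alone gives a low number, while the chloro, fluoro and methyl compounds all sit far higher, and nothing measured here explains this difference.

The compounds shown cannot say whether the low number belongs to the nitro group specifically or would also appear with a nitrile, an amine, a carboxylic acid or a methoxy group at this same carbon. They also leave open whether the nitro group would keep its advantage at another carbon of the same ring, since every group here sits at a single position on the shared core.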